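Dropping the allyloxy group while cytotoxicity sits at its ceiling

This account rests on a few compounds, and the source may have more. Where it says the series, first, only, none or still open, it means among the compounds named here.

Compound 1 `COC(=O)c1cc(C2=C(c3cc(OC)c(OC)c(OC)c3)C(=O)CC2O[SiH2]C(C)(C)C)ccc1OC`, compound 2 `COc1cc(C2=C(c3cc(C)c(OC)c(C)c3)C(O)CC2=O)cc(OC)c1OC` and compound 3 `C=CCOc1cc(C2=C(c3cc(OC)c(OC)c(OC)c3)C(=O)C(O)C2)ccc1OC` were all examined in an ADME assay on L132 cells (Homo sapiens) for cytotoxicity, read by MTT assay, with a stated time of 72 h; a lower number here means a stronger inhibitor, a higher number a weaker inhibitor. Compound 1 reached only a limit of the assay, > 100 ug/mL. Compound 2 likewise gave only a limit, > 100 ug/mL. Compound 3 too stopped at a limit, > 100 ug/mL, and so stands at the limit of > 100 ug/mL in this assay, at which 3 of the 3 values shown sit; nothing among these three compounds sets it apart from the others. The change to compound 4 `COc1ccc(C2=C(c3cc(OC)c(OC)c(OC)c3)C(=O)C(O)C2)cc1` is hydrogen in place of allyloxy on an aromatic carbon. Among the compounds with values here, with no measured step between these compounds to lean on, no shift beyond the usual scatter is expected in this assay, and the step that the limit leaves unreadable from compound 3 to compound 4 is estimated as nothing beyond that scatter. Compound 4 is therefore expected to give 150 ug/mL, within 60 ug/mL to 500 ug/mL, most likely again reported only as a limit.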

Compound 4, half-maximal inhibitory concentration: < 1 ug/mL
Compound 4: no number, only a limit (the forecaster's own chance of this, stated with the estimate: 80%); middle value at least 150-fold (2.17 log units) away from the limit.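

Hydrogen in place of allyloxy, on an aromatic carbon ortho to a methoxy group, gives an at least 100-fold lower number from compound 3 to compound 4 (2.00 log units; beyond the scatter) in this assay, so this position strongly affects the read-out. On these data alone, compound 4 gives < 1 ug/mL, which is a limit of the assay, so the full size of the step stays unknown. Compounds 1 and 2 differ from compound 4 in more than one place, so only compound 3 isolates this change. As far as these compounds go, it remains open whether a hydroxy group or an amine at this position would behave like hydrogen or like allyloxy.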